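The source may report more compounds than this note shows. Statements on the series, on what has been measured and on what is new or still open speak of the compounds shown alone.

The three compounds shown share one core, and compound 1 has the structure `COc1ccc(-c2nc3cc(NC(=O)[C@H](C)Oc4ccccc4CN)ccc3o2)cc1`. In an assay on isolated protein for inhibition of GMP reductase 2 (Homo sapiens), read by spectrophotometry (on this read-out higher numbers stand for weaker inhibition and lower numbers for stronger inhibition), compound 1 gives > 5000 nM, which is a limit of the assay rather than a number. Compound 2, `COc1ccc(-c2cn3cc(NC(=O)[C@H](C)Oc4cccc(Cl)c4Cl)ccc3n2)cc1`, is read in this assay too, and compound 2 gives > 5000 nM, again a limit. Compound 3, `C[C@H](Oc1cccc(Cl)c1Cl)C(=O)Nc1ccc2oc(-c3ccc(O)cc3)nc2c1`, gives in this assay > 5000 nM, once more a limit. Compound 1 therefore stands where every other value shown stands: the limit of > 5000 nM in this assay, at which 3 of the 3 values shown sit. Within the data shown here, no step between measured compounds is available, so nothing shows how a change in the aryl group moves the reading.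

Compound 4, `COc1ccc(-c2nc3cc(NC(=O)[C@H](C)Oc4cccc(F)c4F)ccc3o2)cc1`, differs from compound 1 in one place: 2,3-difluorophenyl in place of 2-(aminomethyl)phenyl on an oxygen on a saturated carbon. With all three values sitting at the limit, no direction can be drawn from them. The expected step is a step that the limit leaves unreadable from compound 1 to compound 4, that is none beyond the scatter. Compound 4 is accordingly expected to give about 10000 nM in this assay, within a range of 3000 nM to 50000 nM, and most likely to be reported once more as a limit.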

Compound 4, inhibition constant: > 5000 nM
Compound 4 gave a limit, no number; the forecaster's own chance of this, stated with the estimate: 85%; the middle value does not contradict the limit.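

No step from compound 1 to compound 4 can be read, as each gives only a limit in this assay: the limit of > 5000 nM in this assay, at which 4 of the 4 values shown sit.

The compounds shown leave open which change to the shared core or its groups, if any, would give an actual number in this assay.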